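The source may hold more compounds than are shown below. What is called first, only, known or untested is meant among the compounds shown, and "the series" means these compounds.

Three compounds share one core and differ only in the aryl group on an amide-type nitrogen. In a functional assay on HT-29 cells (Homo sapiens) for cytotoxicity, read by MTT assay, with a stated time of 72 h (a lower number here means a stronger inhibitor, a higher number a weaker inhibitor), compound 1 `O=C(CN1CCN(c2nnc(Cc3ccncc3)c3ccccc23)CC1)Nc1cccc(F)c1` gives 6130 nM, the smallest of the three numbers, though compound 3 `O=C(CN1CCN(c2nnc(Cc3ccccc3)c3ccccc23)CC1)Nc1ccc(F)c(F)c1` at 9510 nM lies within the scatter of it, while compound 2 `COc1ccc(NC(=O)CN2CCN(c3nnc(Cc4ccccc4)c4ccccc34)CC2)cc1OC` gives 145000 nM. Among the measured compounds shown here, the one step between close neighbours, a 15-fold lower number from compound 2 to compound 3 (1.18 log units; beyond the scatter), shows how far a change at this nitrogen can move the number. Compound 4 `Cc1ccccc1NC(=O)CN1CCN(c2nnc(Cc3ccncc3)c3ccccc23)CC1` differs from compound 1 by 2-methylphenyl in place of 3-fluorophenyl on an amide-type nitrogen. For the measured compounds named here, no measured step replaces a fluorine with a methyl, so that large step supplies a scale but not a direction; only a modest change is expected, a 1.5-fold higher number from compound 1 to compound 4 (0.17 log units; within the scatter). Compound 4 is therefore estimated at 9000 nM, between 3000 nM and 30000 nM.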

Compound 4, half-maximal inhibitory concentration: 15000 nM
Beside the measured number, compound 4's estimate is 1.7-fold (0.22 log units) below it; the measured number falls inside the stated range.
By their numbers in this assay, from the lowest: compounds 1, 3 and 4 (each within the scatter of the next, the first and the last beyond it); then compound 2.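

In this assay, 2-methylphenyl in place of 3-fluorophenyl on the amide-type nitrogen gives a 2.4-fold higher number from compound 1 to compound 4 (0.39 log units; beyond the scatter). This step is smaller than the earlier one between the dimethoxy and difluoro groups, yet it shows that the number still separates two aryl groups with the same heavy-atom count and no hydrogen-bond donors or acceptors. Nothing measured here gives a reason for the step.

Because the substituent changes in both kind and ring position, the shown compounds cannot separate those two changes. On these data alone, how an amine or a carboxylic acid on this aryl ring would read also remains open.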